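Swapping one sulfonyl group on a growth inhibitor

The compounds below may be only part of what the source reports. "The series", "measured", "known", "first", "only" and "open" are said of these compounds alone.

In a functional assay on DU-145 cells (Homo sapiens) for inhibition, read by trypan blue exclusion, with a stated time of 96 h (a higher number here means a weaker inhibitor of growth, a lower number a stronger inhibitor of growth), compound 1 `Cc1ccc(S(=O)(=O)/C(=C/c2sccc2C)C(=O)c2ccc(Br)cc2)cc1` gives 25000 nM and compound 2 `COc1ccc(/C=C(\C(=O)c2ccc(Br)cc2)S(=O)(=O)Cc2ccc(F)cc2)cc1` gives 25000 nM as well, so compound 2 stands level with compound 1. Compound 3 `COc1ccc(/C=C(\C(=O)c2ccc(Br)cc2)S(=O)(=O)c2ccc(C)cc2)cc1` alters one group of compound 2 4-methylphenyl in place of 4-fluorobenzyl on a sulfonyl sulfur and carries 4-methylphenyl in place of 4-fluorobenzyl on a sulfonyl sulfur. Going by the values given here, no measured pair shows this change on its own, so any expectation rests on thin evidence. Compound 1 also holds 4-methylphenyl on its sulfonyl sulfur and gives 25000 nM in this assay even though the rest of its structure differs from compound 2. The step expected here is therefore none beyond the scatter, with a 1.3-fold lower number from compound 2 to compound 3 (0.10 log units; within the scatter) as the estimate. Compound 3 is estimated at 20000 nM with an expected range from 6000 nM to 50000 nM in repeat measurements.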

Compound 3, concentration for 50% growth inhibition: 1000 nM
The estimate for compound 3 lay 20-fold (1.30 log units) above the measured number; measured number outside the range, below it.
By their numbers in this assay, from the lowest: compound 3; then compounds 1 and 2 (each within the scatter of the next).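

In this assay, 4-methylphenyl in place of 4-fluorobenzyl on a sulfonyl sulfur gives a 25-fold lower number from compound 2 to compound 3 (1.40 log units; beyond the scatter) and shows that the group on this sulfur can matter greatly. That group is not enough alone: compound 1 also carries 4-methylphenyl there, and 4-methoxyphenyl in place of 3-methylthiophen-2-yl on a double-bonded chain carbon gives a 25-fold lower number from compound 1 to compound 3 (1.40 log units; beyond the scatter) as a second large change. Among these three compounds, the low number appears only in compound 3, where 4-methylphenyl and 4-methoxyphenyl occur together, while compounds 1 and 2 each hold only one of them.

On these data alone, whether a plain phenyl, a 4-fluorophenyl or a 4-aminophenyl group on the sulfonyl sulfur would keep the low number remains open. Nothing measured here explains why the number falls so far.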